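The source may hold more compounds than are shown below. What is called first, only, known or untested is meant among the compounds shown, and "the series" means these compounds.

Measured compounds:
- compound 1 `COc1cc(-c2nn(-c3cccc(NC(=O)Nc4cccc(C(F)(F)F)c4)c3)cc2-c2ccncc2)ccc1Cl`: 1670 nM
- compound 2 `COc1cc(-c2nn(-c3cccc(NC(=O)c4ccc(Cl)c(C(F)(F)F)c4)c3)cc2-c2ccncc2)ccc1Cl`: 6390 nM

In a functional assay on DU-145 cells (Homo sapiens) for inhibition, read by sulforhodamine B assay, with a stated time of 48 h (a lower number here means a stronger inhibitor of growth, a higher number a weaker inhibitor of growth), compound 2 gives 6390 nM, the highest of the two numbers; its nearest neighbour is compound 1, which in this assay gives 1670 nM. Among the measured compounds shown here, the only recorded step between these two is a 3.8-fold higher number from compound 1 to compound 2 (0.58 log units; beyond the scatter), where a urea was traded for an amide bearing a different aryl group.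

Compound 3 `COc1cc(-c2nn(-c3cccc(NC(=O)Nc4ccc(Cl)c(C(F)(F)F)c4)c3)cc2-c2ccncc2)ccc1Cl` has not yet been measured. It differs from compound 2 by (4-chloro-3-(trifluoromethyl)phenyl)amino in place of 4-chloro-3-(trifluoromethyl)phenyl on a carbonyl carbon. This change restores the urea linkage of compound 1 while keeping the aryl group of compound 2. For the measured compounds named here, the single step that bears on it, a 3.8-fold higher number from compound 1 to compound 2 (0.58 log units; beyond the scatter), ran in the opposite direction on the same linkage, so the expected move is a modest decrease in the number, roughly undoing that step. Compound 3 is therefore estimated at 1500 nM (range 500 nM to 4500 nM), an expected step of a 4.3-fold lower number from compound 2 to compound 3 (0.63 log units; beyond the scatter).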

Compound 3, concentration for 50% growth inhibition: 1500 nM
Compound 3: the middle estimate sits on the measured number at the digits printed, and the stated range covers the measured number.
By their numbers in this assay, from the lowest: compounds 3 and 1 (each within the scatter of the next); then compound 2.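

In this assay, with the 4-chloro-3-(trifluoromethyl)phenyl group held constant, (4-chloro-3-(trifluoromethyl)phenyl)amino in place of 4-chloro-3-(trifluoromethyl)phenyl on the carbonyl carbon gives a 4.3-fold lower number from compound 2 to compound 3 (0.63 log units; beyond the scatter), so the urea-for-amide exchange is now seen on its own, which the earlier step, where the aryl group changed as well, could not show. Within the urea series, chloro in place of hydrogen on an aromatic carbon gives a 1.1-fold lower number from compound 1 to compound 3 (0.05 log units; within the scatter), so the difference between the two aryl groups does not show up in this pair. Nothing in the available data accounts for either step.

From the compounds shown here alone, whether the amide linkage has the same effect with 3-(trifluoromethyl)phenyl as the aryl group remains open. So does how a thiourea or a carbamate on the same carbon, or a methoxy or nitrile group in place of the chloro, would behave.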